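A few compounds are considered here, and "the series" means these few. Any claim that something is new, unique, unknown or untested is made for them only; others in the source may bear on it.

Three compounds share a core in which two benzene rings are joined by a two-carbon bridge, one ring carrying two methoxy groups and a hydroxyl. Compound 1 `COc1cc(CCc2cccc(F)c2)cc(OC)c1O` puts a fluorine on the second ring, compound 2 `COc1cc(CCc2ccc(Cl)cc2)cc(OC)c1O` a chlorine, and compound 3 `COc1ccccc1CCc1cc(OC)c(O)c(OC)c1` a methoxy. They were tested in a functional assay on MDA-MB-231 cells (Homo sapiens) for antiproliferative activity, read by MTT assay, with a stated time of 72 h; on this read-out higher numbers stand for weaker inhibition and lower numbers for stronger inhibition. In this assay compound 1 gives only a limit, > 25000 nM. Compound 2 likewise reaches only the limit, > 25000 nM. Compound 3 also stops at the limit, > 25000 nM. So compound 3 stands nowhere above or below its companions: every value shown is a limit, as the limit of > 25000 nM in this assay, at which 3 of the 3 values shown sit, records, and no measured step between any two of these compounds exists.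

Compound 4 `COc1cc(CCc2ccccc2)cc(OC)c1O` is the unmeasured one. It differs from compound 3 by hydrogen in place of methoxy on an aromatic carbon, the change sitting on an aromatic carbon of a six-membered aromatic ring of carbon only, ortho to a large group. Among the compounds with values here, with no step measured, there is nothing to show that removing the methoxy shifts potency beyond the scatter; the expectation is that compound 4 also falls at or past the limit. The step from compound 3 to compound 4 is thus estimated as a step that the limit leaves unreadable from compound 3 to compound 4. Compound 4 is expected to give about 40000 nM, within a range from 15000 nM to 120000 nM.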

Compound 4, half-maximal inhibitory concentration: > 25000 nM
Compound 4: a limit, no number (the forecaster's own chance of this, stated with the estimate: 80%); the middle value does not contradict the limit.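

No step can be read between compound 1, compound 2, compound 3 and compound 4 in this assay, because all four stop at the same limit: the limit of > 25000 nM in this assay, at which 4 of the 4 values shown sit.

The compounds shown leave open how strong any of the four really is, and whether hydrogen, fluoro, chloro or methoxy on the second ring changes potency at all.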